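Replacing the Ester of Compound 1 with a Cyclic Group

A few compounds are considered here, and "the series" means these few. Any claim that something is new, unique, unknown or untested is made for them only; others in the source may bear on it.

Measured in a functional assay on Jurkat cells for inhibition of nuclear factor NF-kappa-B complex (Homo sapiens) (a higher number here means a weaker inhibitor, a lower number a stronger inhibitor), so far:
compound 1 `CCOC(=O)c1cnc(-c2cccs2)nc1NN1C(=O)C=C(C)C1=O` gives 20 nM
compound 2 `CCOC(=O)c1cnc(-c2ccc(C)s2)nc1NN1C(=O)C=C(C)C1=O` gives 200 nM
compound 3 `CCOC(=O)c1cnc(Cc2ccccc2)nc1NN1C(=O)C=C(C)C1=O` gives 7000 nM

Compound 1 stands lowest of the three; the nearest is a 10-fold higher number from compound 1 to compound 2 (1.00 log units; beyond the scatter) and the furthest is a 350-fold higher number from compound 1 to compound 3 (2.54 log units; beyond the scatter). Compound 4 `CC1=CC(=O)N(Nc2nc(-c3cccs3)ncc2C2=NCCO2)C1=O` differs from it by a group of 5 heavy atoms (3 carbon, 1 nitrogen, 1 oxygen; one five-membered non-aromatic ring with 2 hetero atoms) in place of a group of 5 heavy atoms (3 carbon, 2 oxygen; no ring), on an aromatic carbon. Going by the values given here, none of the measured steps touches this position: they concern the thiophen-2-yl group and its methyl, and the step of a 35-fold higher number from compound 2 to compound 3 (1.54 log units; beyond the scatter) likewise. Nothing shown therefore speaks directly to the change, so a modest weakening is expected rather than a large one. Compound 4 is estimated at 60 nM, within 15 nM to 400 nM, meaning an expected 3.0-fold higher number from compound 1 to compound 4 (0.48 log units; beyond the scatter).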

Compound 4, half-maximal inhibitory concentration: 200 nM
The estimate for compound 4 lay 3.3-fold (0.52 log units) below the measured number, and the stated range covers the measured number.
By their numbers in this assay, from the lowest: compound 1; then compounds 2 and 4 (each within the scatter of the next); then compound 3.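

Unlike the earlier steps, this one changes the ethoxycarbonyl group itself, and in this assay the five-membered non-aromatic ring with 2 hetero atoms that replaces it gives a 10-fold higher number from compound 1 to compound 4 (1.00 log units; beyond the scatter). The position is therefore sensitive to this change, even though the heavy-atom, donor and acceptor counts of the two groups are the same. Nothing shown gives a reason for this step.

Going by these compounds, whether a carboxylic acid, a primary amide or a methyl ester here would stay closer to compound 1 remains open. So does whether the step would be the same with the 5-methylthiophen-2-yl or benzyl group in place of thiophen-2-yl.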